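The source may hold more compounds than are shown below. What is called first, only, known or untested is meant among the compounds shown, and "the series" means these compounds.

In a physicochemical assay for lipophilicity, read by HPLC, in phosphate buffer, measured as octanol-water partition, with a stated time of 1 h, at pH 7.4 (a higher number here means a more lipophilic compound, a lower number a more polar compound), compound 1 `Cc1cc(C#N)cnc1C(=O)Nc1ccc(F)c([C@]2(C)C=C(CF)OC(N)=N2)c1` gives 2.5, the second highest of three numbers. Compound 3 `Cc1cc(C#N)cnc1C(=O)Nc1ccc(F)c([C@]2(C)C=C(C(F)F)OC(N)=N2)c1` stands higher at 2.9, and compound 2 `CC1=COC(N)=N[C@]1(C)c1cc(NC(=O)c2ccc(C#N)cn2)ccc1F` stands lower at 1.5. Compound 4 `COc1cc(C#N)cnc1C(=O)Nc1ccc(F)c([C@]2(C)C=C(CF)OC(N)=N2)c1` has not yet been measured. It differs from compound 1 in one place, methoxy in place of methyl on an aromatic carbon, turning 5-cyano-3-methylpyridin-2-yl into 5-cyano-3-methoxypyridin-2-yl. Within the data shown here, only one measured step is available, a number 0.40 log units higher from compound 1 to compound 3 (beyond the scatter). That modest step concerns fluoro in place of hydrogen on a saturated chain carbon, so it gives no direct measure of a change at this aromatic carbon. Compound 2 differs from compound 1 in more than one place, and its value cannot be assigned to any single change. Among the measured compounds shown here, with no measured precedent, only a small downward move is expected in this assay, probably not beyond the scatter. The expected step is a number 0.20 log units lower from compound 1 to compound 4 (within the scatter). For compound 4 the estimated value is 2.3, with an expected range of 1.9 to 2.7.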

Compound 4, distribution coefficient: 1.9
Beside the measured number, compound 4's estimate is 0.40 log units above it; the range from low to high includes it.
By their numbers in this assay, from the lowest: compound 2; then compound 4; then compound 1; then compound 3.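

Among these compounds, replacing methyl with methoxy on this aromatic carbon, which turns 5-cyano-3-methylpyridin-2-yl into 5-cyano-3-methoxypyridin-2-yl, gives a number 0.60 log units lower from compound 1 to compound 4 (beyond the scatter) in this assay and is the first single change measured at this position. Among the compounds shown here, the only earlier single change, made on the saturated chain, was a number 0.40 log units higher from compound 1 to compound 3 (beyond the scatter) and ran the other way, so the number can be moved beyond the scatter in either direction from compound 1 by one change at either of two separate places. No measurement shown here explains the drop at the aromatic carbon.

The compounds shown carry only methyl and methoxy at this carbon, so it remains open where an ethoxy group, a hydroxyl group or an amine there would fall. Also open, from the compounds shown here alone, is whether the same exchange would give a step of like size on the core of compound 3.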